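Piperazine for fluoro on the shared core

A few compounds are considered here, and "the series" means these few. Any claim that something is new, unique, unknown or untested is made for them only; others in the source may bear on it.

Compound 2 `CN1CCN(c2ccc(-c3nc(-c4ccc(-c5nc(-c6ccc(F)cc6)c(-c6ccc(N7CCN(C)CC7)cc6)[nH]5)cc4)[nH]c3-c3ccc(N4CCN(C)CC4)cc3)cc2)CC1` stands highest of the three numbers in an ADME assay on nucleic acid for binding affinity to Quadruplex DNA (Homo sapiens), read by spectrophotometry and circular dichroism, tested at 6 uM (a higher number here means that the compound stabilises the target more against heat, a lower number that the compound stabilises the target less), with 6.5 degrees C; compound 3 `CN1CCN(c2ccc(-c3nc(-c4ccc(-c5nc(-c6ccc(F)cc6)c(-c6ccc(F)cc6)[nH]5)cc4)[nH]c3-c3ccc(N4CCN(C)CC4)cc3)cc2)CC1` gives 6.1 degrees C, and compound 1 `CN1CCN(c2ccc(-c3nc(-c4ccc(-c5nc(-c6ccc(F)cc6)c(-c6ccc(N7CCN(C)CC7)cc6)[nH]5)cc4)[nH]c3-c3ccc(F)cc3)cc2)CC1` gives 1.7 degrees C. Toward compound 3 the step is a number 0.40 degrees C lower from compound 2 to compound 3 (within the scatter), within the scatter, whereas a number 4.8 degrees C higher from compound 1 to compound 2 (beyond the scatter) lies beyond it.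

Compound 4 `CN1CCN(c2ccc(-c3nc(-c4ccc(-c5nc(-c6ccc(N7CCN(C)CC7)cc6)c(-c6ccc(N7CCN(C)CC7)cc6)[nH]5)cc4)[nH]c3-c3ccc(N4CCN(C)CC4)cc3)cc2)CC1` differs from compound 2 by 4-methylpiperazin-1-yl in place of fluoro on an aromatic carbon. The same exchange gave a number 4.8 degrees C higher from compound 1 to compound 2 (beyond the scatter) at one site and, in reverse, only a number 0.40 degrees C lower from compound 2 to compound 3 (within the scatter) at another, so the two measured steps disagree on size. A modest rise is expected, a number 2.0 degrees C higher from compound 2 to compound 4 (beyond the scatter), because a number 4.8 degrees C higher from compound 1 to compound 2 (beyond the scatter) was large while a number 0.40 degrees C lower from compound 2 to compound 3 (within the scatter) stayed within scatter. Compound 4 is therefore estimated at 8.5 degrees C in this assay, ranging from 6 degrees C to 11.5 degrees C.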

Compound 4, shift of the target's melting temperature: 8.9 degrees C
Beside the measured number, compound 4's estimate is 0.40 degrees C below it; low and high end bracket the measured number.
By their numbers in this assay, from the lowest: compound 1; then compounds 3 and 2 (each within the scatter of the next); then compound 4.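

In this assay, the exchange of fluoro for 4-methylpiperazin-1-yl at this site gives a number 2.4 degrees C higher from compound 2 to compound 4 (beyond the scatter) even though compound 2 already carries that group elsewhere. The shared exchange is thus not spent after earlier additions, although this modest rise stays smaller than a number 4.8 degrees C higher from compound 1 to compound 2 (beyond the scatter) at the other site. Compound 4 keeps no fluoro at all.

On these data alone, whether a smaller amine such as dimethylamino, or a longer chain carrying the piperazine, would hold this rise remains open. Nothing available explains the size of the step.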